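Hydroxyamino at the chain end of compound 2

A few compounds are considered here, and "the series" means these few. Any claim that something is new, unique, unknown or untested is made for them only; others in the source may bear on it.

Measured so far in an assay on isolated protein for inhibition of Myeloperoxidase (Homo sapiens), read by ELISA, with a stated time of 5 min; on this read-out lower numbers stand for stronger inhibition and higher numbers for weaker inhibition:
compound 1, `NCCCCc1c[nH]c2c(F)cccc12`: 21 nM
compound 2, `CCCc1c[nH]c2ccc(F)cc12`: > 100 nM
compound 3, `NC(=O)CCc1c[nH]c2c(F)cccc12`: 64 nM

In this assay compound 2 gives only a limit, > 100 nM, and so sits at the limit of > 100 nM in this assay, at which 1 of the 3 values shown sits, the weak end of what has been measured. Compound 4, `ONCCCc1c[nH]c2ccc(F)cc12`, differs from it by hydroxyamino in place of hydrogen on a saturated chain carbon, three bonds along the chain from an aromatic carbon. For the measured compounds named here, no measured step covers this change. Going by the values given here, the one measured step, a 3.0-fold higher number from compound 1 to compound 3 (0.48 log units; beyond the scatter), concerns the far end of a comparable chain: compound 1, whose chain ends in an amine, gives 21 nM, and compound 3, whose chain ends in carbamoyl, gives 64 nM; both return numbers rather than a limit. On that ground a gain is expected for compound 4, an at least 2.2-fold lower number from compound 2 to compound 4 (0.34 log units; beyond the scatter). Compound 4 is estimated at 45 nM, within 12 nM to 200 nM.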

Compound 4, half-maximal inhibitory concentration: 21 nM
For compound 4 the middle estimate is 2.1-fold (0.33 log units) above the measured one; the measured number falls inside the stated range.
By their numbers in this assay, from the lowest: compounds 1 and 4 (each within the scatter of the next); then compound 3. At a limit, above all of these: compound 2.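

Hydroxyamino in place of hydrogen on a saturated chain carbon, three bonds along the chain from an aromatic carbon, gives an at least 4.7-fold lower number from compound 2 to compound 4 (0.67 log units; beyond the scatter) in this assay. With the core unchanged, this change at the chain end alone moves the read-out beyond the scatter. The true size of the gain stays open because the starting point is a limit: the limit of > 100 nM in this assay, at which 1 of the 4 values shown sits.

Open, on these data alone, is whether a plain amine or a carboxylic acid at the same chain end would match hydroxyamino. Also open, as far as these compounds go, is whether a longer chain carrying hydroxyamino would keep the gain.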